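Swapping the methoxy of compound 3 for fluoro

This account rests on a few compounds, and the source may have more. Where it says the series, first, only, none or still open, it means among the compounds named here.

Measured compounds:
- compound 1, `O=c1c2ccccc2[se]n1-c1nnc(-c2ccc(Br)cc2)s1`, 43300 nM
- compound 2, `O=c1c2ccccc2[se]n1-c1nnc(-c2ccc(Cl)cc2)s1`, 19500 nM
- compound 3, `COc1ccc(-c2nnc(-n3[se]c4ccccc4c3=O)s2)cc1`, 10000 nM

All three share one core and differ only in the group on the outer benzene ring. In a functional assay on MCF7 cells (Homo sapiens) for antiproliferative activity, read by CCK-8 assay, with a stated time of 48 h (on this read-out higher numbers stand for weaker inhibition and lower numbers for stronger inhibition), compound 3 gives the lowest of the three numbers. Its step to compound 1 is clear: a 4.3-fold lower number from compound 1 to compound 3 (0.64 log units; beyond the scatter). Its step to compound 2 is not: a 2.0-fold lower number from compound 2 to compound 3 (0.29 log units; within the scatter), so compound 2 and compound 3 cannot be told apart on these data.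

Compound 4, `O=c1c2ccccc2[se]n1-c1nnc(-c2ccc(F)cc2)s1`, is compound 3 with one change: fluoro in place of methoxy on an aromatic carbon. For the measured compounds named here, no measured step covers methoxy against fluoro directly. Two kinds of step bear on it. The halogen-to-halogen step, a 2.2-fold lower number from compound 1 to compound 2 (0.35 log units; beyond the scatter), and the halogen-to-methoxy steps, a 4.3-fold lower number from compound 1 to compound 3 (0.64 log units; beyond the scatter) and a 2.0-fold lower number from compound 2 to compound 3 (0.29 log units; within the scatter), show that moving from bromo through chloro to methoxy gives steadily lower numbers. Fluoro is a third halogen, so compound 4 is expected to land near compound 2 or compound 3, with a step from compound 3 that is estimated as a 1.5-fold higher number from compound 3 to compound 4 (0.18 log units; within the scatter), within the scatter or slightly above it. Compound 4 is therefore estimated at 15000 nM, with a likely range from 6000 nM to 40000 nM.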

Compound 4, half-maximal inhibitory concentration: 61500 nM
For compound 4 the middle estimate is 4.1-fold (0.61 log units) below the measured one; measured number above the stated range.
By their numbers in this assay, from the lowest: compounds 3 and 2 (each within the scatter of the next); then compounds 1 and 4 (each within the scatter of the next).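

In this assay, fluoro is no stand-in for methoxy on this aromatic carbon, para to a large group, as the change gives a clear loss of inhibition (a 6.2-fold higher number from compound 3 to compound 4 (0.79 log units; beyond the scatter)). The halogens also fail to form a simple series: the earlier drop in the number from bromo to chloro does not carry on to fluoro, which sits clearly above chloro (a 3.2-fold higher number from compound 2 to compound 4 (0.50 log units; beyond the scatter)) yet cannot be told apart from bromo (a 1.4-fold higher number from compound 1 to compound 4 (0.15 log units; within the scatter)), so chloro differs from the halogens on either side of it in the periodic table and the lightest one offers no gain at this position. No measurement among these compounds accounts for this pattern.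

With only one non-halogen group in the set, the compounds shown leave open whether the lower number of compound 3 is particular to methoxy or would also appear with a hydroxyl, an ethoxy, a methyl or an amine in the same place. They also leave open how far any of these groups would change the number when the shared core itself is altered.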